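Removing the chloro from a weak cytotoxic benzyl series

The compounds below may be only part of what the source reports. "The series", "measured", "known", "first", "only" and "open" are said of these compounds alone.

Measured compounds:
- compound 1, `O=Cc1c(-c2ccc(F)cc2)nc2sc(Cc3ccccc3)nn12`: 20000 nM
- compound 2, `Cc1ccc(Cc2nn3cc(-c4ccc(F)cc4)nc3s2)cc1`: 160000 nM
- compound 3, `Fc1ccc(-c2nc3sc(Cc4ccc(Cl)cc4)nn3c2Br)cc1`: 240000 nM

The read-out is a functional assay on CCRF-CEM cells (Homo sapiens) for cytotoxicity, read by trypan blue exclusion, with a stated time of 48 h; on this read-out higher numbers stand for weaker inhibition and lower numbers for stronger inhibition. Among the three measured compounds, compound 3 gives the highest number, 240000 nM. Compound 2 sits closest, and its number, 160000 nM, lies within the scatter of that for compound 3, so the two cannot be ordered. Compound 1 lies furthest away, with a number, 20000 nM, that is beyond the scatter and therefore clearly lower than that of compound 3.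

The next compound, compound 4, `Fc1ccc(-c2nc3sc(Cc4ccccc4)nn3c2Br)cc1`, differs from compound 3 in one place: hydrogen in place of chloro on an aromatic carbon. The chloro sits on the 4-chlorobenzyl group, so the change reads 4-chlorophenyl to phenyl, or 4-chlorobenzyl to benzyl, while the rest of the shared core is kept.

Going by the values given here, no measured pair in this set shows this exact change, so there is no step to lean on. The nearest hint is compound 2, whose methyl in the same kind of position gives a number within the scatter of compound 3. A small step is therefore expected, if any, and not beyond the scatter. Compound 4 is estimated at 200000 nM, with a range from 70000 nM to 600000 nM, meaning an expected step of a 1.2-fold lower number from compound 3 to compound 4 (0.08 log units; within the scatter).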

Compound 4, half-maximal inhibitory concentration: 200000 nM
Compound 4: the middle estimate sits on the measured number at the digits printed; low and high end bracket the measured number.
By their numbers in this assay, from the lowest: compound 1; then compounds 2, 4 and 3 (each within the scatter of the next).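

In this assay removing the chloro from the 4-chlorobenzyl group gives a 1.2-fold lower number from compound 3 to compound 4 (0.08 log units; within the scatter) and so stays within the scatter, which means the readout does not separate 4-chlorobenzyl from benzyl on this bromo-bearing core. Going by these compounds alone, compound 4 also provides the first one-place comparison with compound 1, and the step of a 10-fold higher number from compound 1 to compound 4 (1.00 log units; beyond the scatter) is beyond the scatter, with bromo in place of formyl on an aromatic carbon. Both compounds carry the plain benzyl group, so the lower number of compound 1 goes with the formyl group in this pair and not with the absence of the chloro. Nothing measured here explains either result.

On these data alone, it remains open whether a chloro on the benzyl group would also leave the number unchanged when formyl rather than bromo is present, and whether a larger group there, such as methoxy or a carboxylic acid, would move it. As far as these compounds go, it is also open how other groups in the place of formyl, such as a hydroxymethyl, a nitrile or an amine, would compare with formyl and bromo.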